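The source may hold more compounds than are shown below. What is called first, only, known or untested is meant among the compounds shown, and "the series" means these compounds.

In a physicochemical assay for lipophilicity, read by HPLC, with a stated time of 90 min, tested at 100 uM (on this read-out lower numbers stand for lower lipophilicity and higher numbers for higher lipophilicity), compound 2 `Cc1ccoc1C(=O)N1CCC(NC(=O)Nc2ccc(OC(F)(F)F)cc2)CC1` gives 4.48. Compound 1 `Cc1ccoc1C(=O)N1CCC(NC(=O)Nc2ccc(C(F)(F)F)cc2)CC1`, at 4.29, cannot be separated from it, while compound 3 `O=C(Nc1ccc(C(F)(F)F)c(F)c1)NC1CCN(C(=O)C2(C(F)(F)F)CC2)CC1` stands clearly higher at 5.52. The next compound to read is compound 4 `O=C(Nc1ccc(OC(F)(F)F)cc1)NC1CCN(C(=O)c2ccoc2)CC1`, which keeps the trifluoromethoxy group of compound 2 and carries furan-3-yl in place of 3-methylfuran-2-yl on a carbonyl carbon.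

Within the data shown here, the only measured step between close pairs is a number 0.19 log units higher from compound 1 to compound 2 (within the scatter). It concerns trifluoromethoxy in place of trifluoromethyl on an aromatic carbon, so it bears on this change only indirectly. Among the measured compounds shown here, no measured pair isolates the group on the carbonyl carbon, and compound 3 differs from compound 2 in more than one place. The expectation is therefore loose: starting from compound 2 at 4.48, with a smaller entering group, a modest fall in this assay is expected, close to the edge of the scatter. The estimated change is a number 0.38 log units lower from compound 2 to compound 4 (beyond the scatter). For compound 4 the expected value is 4.1, with an estimated range of 3.7 to 4.5.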

Compound 4, partition coefficient: 3.63
For compound 4 the middle estimate is 0.47 log units above the measured one, and the stated range ends above it.
By their numbers in this assay, from the lowest: compound 4; then compounds 1 and 2 (each within the scatter of the next); then compound 3.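

In this assay, furan-3-yl in place of 3-methylfuran-2-yl on a carbonyl carbon gives a number 0.85 log units lower from compound 2 to compound 4 (beyond the scatter) and places compound 4 lowest of the four compounds. Among these compounds, this is the first measured step at this carbonyl carbon, and it shows that a change here can move the read-out beyond the scatter, whereas the one earlier step, on an aromatic carbon, stayed within it. The step combines the loss of the methyl group with a change in how the furan is attached, and no evidence on hand explains its size.

As far as these compounds go, whether the step follows the methyl group or the attachment remains open, and furan-2-yl on this carbonyl carbon would separate the two. Also open, from the compounds shown here alone, is whether the same exchange gives a similar step with trifluoromethyl in place of trifluoromethoxy on the aromatic carbon.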